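Removing one methoxy from the aryl ring of compound 3

The source may report more compounds than this note shows. Statements on the series, on what has been measured and on what is new or still open speak of the compounds shown alone.

Measured so far in an assay on isolated protein for inhibition of lysosomal alpha-glucosidase (Rattus norvegicus), read by spectrophotometry, with a stated time of 5 min, tested at 25 ug/mL; a higher number here means more inhibition at the concentration tested (going by the name of the read-out), a lower number less inhibition:
- compound 1 `COc1ccc(/C=C/C(=O)c2cc3ccoc3cc2O)cc1`: 48.9%
- compound 2 `O=C(/C=C/c1ccc(O)cc1)c1cc2ccoc2cc1O`: 8.77%
- compound 3 `COc1cc(OC)c(OC)cc1/C=C/C(=O)c1cc2ccoc2cc1O`: 68%

Compound 3 stands highest of the three numbers in this assay; compound 1 lies nearest, and compound 2 lies furthest below it. Among the compounds with values here, the only step between compounds differing in one place is a number 40.1 percentage points lower from compound 1 to compound 2 (beyond the scatter), a large drop on replacing a methyl with hydrogen on an oxygen on the aromatic ring.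

Compound 4 `COc1ccc(/C=C/C(=O)c2cc3ccoc3cc2O)cc1OC` is not yet measured. It differs from compound 3 by hydrogen in place of methoxy on an aromatic carbon. Within the data shown here, no measured step removes a whole methoxy, so the closest guide is the comparison of compound 3 with compound 1, which carries a single methoxy on that ring and gives the lower number. Two methoxy groups remain in compound 4, so a modest decrease from compound 3 is expected, with the step of a number 11 percentage points lower from compound 3 to compound 4 (beyond the scatter) estimated as small to moderate. Compound 4 is therefore expected to give about 57% in this assay, within a range from 40% to 72%.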

Compound 4, a percentage reported as inhibition, at one concentration (the size of the read-out at that concentration, not a potency): 89.4%
Compound 4: the middle estimate sits 32.4 percentage points below what was measured; measured number outside the range, above it.
By their numbers in this assay, from the lowest: compound 2; then compound 1; then compound 3; then compound 4.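

In this assay, a methoxy group on this ring does not shift the number in one direction: adding one gives a number 40.5 percentage points higher from compound 1 to compound 4 (beyond the scatter), whereas hydrogen in place of methoxy gives a number 21.4 percentage points higher from compound 3 to compound 4 (beyond the scatter). The second step shows that, at the aromatic carbon ortho to a large group, meta to a methoxy group and para to a methoxy group, methoxy is not needed for high inhibition, and compound 4 carries hydrogen there. No supporting data bear on why these two methoxy changes run in opposite directions.

Open, on these data alone, is whether inhibition at this aromatic carbon is specific to hydrogen or also holds with a fluorine atom, an ethoxy group or an amine. Also open, as far as these compounds go, is whether the rise seen on adding methoxy to compound 1 would carry over to a hydroxy or ethoxy group at that same place.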